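Swapping a Furan for a Methylthiophene on the Aryl Ring

The source may hold more compounds than are shown below. What is called first, only, known or untested is meant among the compounds shown, and "the series" means these compounds.

Measured so far:
Compound 1 `Cn1nc2c(=O)n(CC3(O)CCN(Cc4ccc(-c5n[nH]c(=O)o5)cc4Cl)CC3)cnc2c1-c1ccc(CN)cc1`: 171 nM
Compound 2 `Cn1nc2c(=O)n(CC3(O)CCN(Cc4ccc(-c5ccoc5)cc4Cl)CC3)cnc2c1-c1ccc(CN)cc1`: 177 nM

Both compounds were tested in an assay on isolated protein for inhibition of ubiquitin carboxyl-terminal hydrolase 7 (Homo sapiens), with stated times of 30 min and 2 h; on this read-out lower numbers stand for stronger inhibition and higher numbers for weaker inhibition. In this assay compound 1 gives 171 nM, and compound 2 gives 177 nM. Compound 2 stands level with compound 1 within the usual scatter, so on these two numbers neither can be set apart from the other. Among the measured compounds shown here, the only measured step, a 1.0-fold higher number from compound 1 to compound 2 (0.01 log units; within the scatter), exchanged one five-membered aromatic ring for another at the same aromatic carbon and left the read-out essentially unchanged.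

Compound 3 `Cc1ccc(-c2ccc(CN3CCC(O)(Cn4cnc5c(-c6ccc(CN)cc6)n(C)nc5c4=O)CC3)c(Cl)c2)s1` differs from compound 2 by 5-methylthiophen-2-yl in place of furan-3-yl on an aromatic carbon. For the measured compounds named here, this is again an exchange of one five-membered aromatic ring for another at the same place, and the one measured step of that kind was within the scatter. The step of a 1.0-fold higher number from compound 2 to compound 3 (0.01 log units; within the scatter) is therefore expected to stay within the scatter as well. Compound 3 is estimated at 180 nM, with a range from 70 nM to 460 nM.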

Compound 3, half-maximal inhibitory concentration: 101 nM
The estimate for compound 3 lay 1.8-fold (0.25 log units) above the measured number, and the stated range covers the measured number.
By their numbers in this assay, from the lowest: compounds 3, 1 and 2 (each within the scatter of the next).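

In this assay, the exchange at this aromatic carbon, para to a large group, gives a 1.8-fold lower number from compound 2 to compound 3 (0.24 log units; within the scatter), so a ring with sulfur and a methyl group cannot be told apart from furan-3-yl on this read-out. Set against the ring of compound 1, which has three hetero atoms, 5-methylthiophen-2-yl gives a 1.7-fold lower number from compound 1 to compound 3 (0.23 log units; within the scatter), which also lies within the scatter. All three five-membered aromatic rings at this place therefore give numbers that cannot be separated, even though their atoms differ considerably, and nothing available here bears on this result. The compounds shown leave open how a group other than a five-membered aromatic ring, such as an amine or a carboxylic acid, would read out at this place. They also leave open what the methyl group contributes on its own, which a comparison with unsubstituted thiophen-2-yl could address.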